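Swapping chloro for trifluoromethyl on the second indazole core

The compounds below may be only part of what the source reports. "The series", "measured", "known", "first", "only" and "open" are said of these compounds alone.

Measured so far, in a functional assay on CHO cells for positive allosteric modulation of muscarinic acetylcholine receptor M5 (Homo sapiens), read by calcium flux; a lower number here means a smaller maximal response, a higher number a larger maximal response:
compound 1, `CCN(Cc1ccccc1Cl)C(=O)C1CCN(S(=O)(=O)c2ccc3cn[nH]c3c2)CC1`, gives 93%
compound 2, `CCN(Cc1ccccc1C(F)(F)F)C(=O)C1CCN(S(=O)(=O)c2ccc3cn[nH]c3c2)CC1`, gives 92%
compound 3, `CCN(Cc1ccccc1Cl)C(=O)C1CCN(S(=O)(=O)c2ccc3[nH]ncc3c2)CC1`, gives 78%

Compound 1 and compound 2 differ only by trifluoromethyl in place of chloro on an aromatic carbon, and this change made a step of a number 1 percentage points lower from compound 1 to compound 2 (within the scatter). The two cores differ by 1H-indazol-5-yl in place of 1H-indazol-6-yl on a sulfonyl sulfur, a step of a number 15 percentage points lower from compound 1 to compound 3 (beyond the scatter).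

Compound 4, `CCN(Cc1ccccc1C(F)(F)F)C(=O)C1CCN(S(=O)(=O)c2ccc3[nH]ncc3c2)CC1`, is not yet measured. It differs from compound 3 by trifluoromethyl in place of chloro on an aromatic carbon, the same change already made from compound 1 to compound 2, at a place described in the same words. For compound 4 the expected step is therefore a number 1 percentage points lower from compound 3 to compound 4 (within the scatter), resting on the earlier step of a number 1 percentage points lower from compound 1 to compound 2 (within the scatter) in this assay. Compound 4 is thus estimated at 77%, expected between 65% and 89%.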

Compound 4, largest response reached (reported as percent of maximum), in percent of the reference or control that the assay uses: 96%
Compound 4: middle estimate off by 19 percentage points, on the low side; measured number outside the range, above it.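

In this assay, trifluoromethyl in place of chloro gave a number 18 percentage points higher from compound 3 to compound 4 (beyond the scatter), so the near-silent swap on the core of compound 1 did not carry over to the second core: the same change on two cores in this assay, a number 1 percentage points lower (within the scatter) from compound 1 to compound 2 and a number 18 percentage points higher (beyond the scatter) from compound 3 to compound 4, 19 percentage points apart, beyond the scatter of two such steps

Seen from the other side, 1H-indazol-5-yl in place of 1H-indazol-6-yl gave a number 4 percentage points higher from compound 2 to compound 4 (within the scatter) with trifluoromethyl present, which differs from the step seen with chloro: the same change on two cores in this assay, a number 15 percentage points lower (beyond the scatter) from compound 1 to compound 3 and a number 4 percentage points higher (within the scatter) from compound 2 to compound 4, 19 percentage points apart, beyond the scatter of two such steps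

So in these four compounds the effect of each change depends on the other, but the data do not show why, nor whether this holds beyond this set.

The compounds shown leave open how a methoxy group or a nitrile at the same place would behave on either core.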